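Benzyloxy in Place of Hydroxy on a Nitro-Substituted Core

The source may hold more compounds than are shown below. What is called first, only, known or untested is meant among the compounds shown, and "the series" means these compounds.

Measured compounds:
compound 1 `CS(=O)(=O)N1CC(CCl)c2cc([N+](=O)[O-])c(O)cc21`, 8.85 ug/mL
compound 2 `CS(=O)(=O)OCC1CN(S(C)(=O)=O)c2cc(O)c([N+](=O)[O-])cc21`, 0.764 ug/mL

In a functional assay on KB cells (Homo sapiens), read by crystal violet staining (a higher number here means a weaker inhibitor, a lower number a stronger inhibitor), compound 2 gives the lowest of the two numbers; the step of a 12-fold lower number from compound 1 to compound 2 (1.06 log units; beyond the scatter) separates it from compound 1. Compound 3 `CS(=O)(=O)OCC1CN(S(C)(=O)=O)c2cc(OCc3ccccc3)c([N+](=O)[O-])cc21` differs from compound 2 by benzyl in place of hydrogen on an oxygen on an aromatic ring. Within the data shown here, no measured step touches the oxygen on the aromatic ring, so the only step on record, from chloro to (methylsulfonyl)oxy, does not bear on this change. With no guide, a step toward a higher number is assumed for compound 3, with wide uncertainty. Compound 3 is therefore expected to give 5 ug/mL, between 0.5 ug/mL and 50 ug/mL. That estimate means an expected step of a 6.5-fold higher number from compound 2 to compound 3 (0.82 log units; beyond the scatter).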

Compound 3, half-maximal inhibitory concentration: 7.91 ug/mL
Compound 3: middle estimate off by 1.6-fold (0.20 log units), on the low side, and the stated range covers the measured number.
By their numbers in this assay, from the lowest: compound 2; then compounds 3 and 1 (each within the scatter of the next).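

In this assay, among these compounds, benzyl in place of hydrogen on the oxygen on the aromatic ring gives a 10-fold higher number from compound 2 to compound 3 (1.02 log units; beyond the scatter), the first measured change at this oxygen. With (methylsulfonyl)oxy held constant on the chain, this position is shown to be one where a single change moves the number beyond the scatter. No evidence on hand accounts for this step.

The compounds shown leave open whether methyl or a simple ethyl ether on this oxygen would give a similar step. They also leave open whether benzyloxy would have the same effect with chloro on the chain.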